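The source may hold more compounds than are shown below. What is called first, only, known or untested is meant among the compounds shown, and "the series" means these compounds.

Among the measured compounds shown here, compound 2 `Cc1ccc(C(=O)N/N=C/C2=C(Cl)c3ccccc3CCC2)cc1` is the only compound of the three measured that gives a number in a functional assay on HeLa cells (Homo sapiens) for inhibition, read by sulforhodamine B assay, with a stated time of 48 h; a lower number here means a stronger inhibitor of growth, a higher number a weaker inhibitor of growth: compound 2 gives 300 nM. Compound 1 `O=C(N/N=C/C1=C(Cl)c2ccccc2CCC1)c1ccccc1` gives > 100000 nM, which is a limit of the assay. Compound 3 `Nc1ccccc1C(=O)N/N=C/C1=C(Cl)c2ccccc2CCC1` likewise gives > 100000 nM, again a limit. Two of the measured steps are large and one cannot be read: the step of an at least 330-fold lower number from compound 1 to compound 2 (2.52 log units; beyond the scatter), the step of an at least 330-fold higher number from compound 2 to compound 3 (2.52 log units; beyond the scatter), and the step that the two limits leave unreadable from compound 1 to compound 3. The reading of both large steps rests on (the limit of > 100000 nM in this assay, at which 2 of the 3 values shown sit).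

Compound 4 `O=C(N/N=C/C1=C(Cl)c2ccccc2CCC1)c1ccc([N+](=O)[O-])cc1` differs from compound 2 in one place: nitro in place of methyl on an aromatic carbon. For the measured compounds named here, the methyl that enters from compound 1 to compound 2 is the group that leaves here, and that step was large; no measured step covers the nitro that enters. Compound 4 is therefore expected to stand weaker than compound 2, with the step of a 10-fold higher number from compound 2 to compound 4 (1.00 log units; beyond the scatter) as the estimate. Compound 4 is estimated at 3000 nM, within a range from 300 nM to 100000 nM.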

Compound 4, concentration for 50% growth inhibition: > 100000 nM
Compound 4 was reported as a limit; the forecaster's own chance of this, stated with the estimate: 30%; middle value at least 33-fold (1.52 log units) away from the limit.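

Nitro in place of methyl on the aromatic carbon para to a large group gives an at least 330-fold higher number from compound 2 to compound 4 (2.52 log units; beyond the scatter) in this assay, so a second group at this position does not keep the growth inhibition that methyl gives. Compound 4 gives > 100000 nM, which is a limit of the assay. The step between compound 1 and compound 4 cannot be read, and the size of the large step rests on a limit: the limit of > 100000 nM in this assay, at which 3 of the 4 values shown sit.

The compounds shown leave open whether the number of compound 2 depends on methyl alone, or whether an ethyl, a methoxy or a chlorine at this position would also give a number. They also leave open how a methyl would fare elsewhere on that ring.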